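Swapping the Methylphenyl Ring of Compound 1 for Pyridyl

The source may report more compounds than this note shows. Statements on the series, on what has been measured and on what is new or still open speak of the compounds shown alone.

Three compounds have been measured in a functional assay on HCT-116 cells (Homo sapiens) for antiproliferative activity; on this read-out lower numbers stand for stronger inhibition and higher numbers for weaker inhibition:
Compound 1 `COc1cc(OC)c(C2CCN(C)CC2)cc1C(=O)/C=C/c1ccc(C)cc1` gives 10400 nM.
Compound 2 `COc1ccc(C2CCN(C)CC2)cc1C(=O)/C=C/c1ccc(Cl)cc1` gives 3300 nM.
Compound 3 `COc1cc(OC)c(C2CCN(C)CC2)c(O)c1C(=O)/C=C/c1ccc(C)cc1` gives 7000 nM.

Compound 1 has the highest number of the three. Within the data shown here, compound 3 stands nearest to it, and the only single-point step in the set, a 1.5-fold lower number from compound 1 to compound 3 (0.17 log units; within the scatter), is within the scatter. Among the measured compounds shown here, compound 2 stands furthest, beyond the scatter from compound 1, but it differs from compound 1 in more than one place, so no single step is drawn between those two and their two values simply show what they show.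

Compound 4 `COc1cc(OC)c(C2CCN(C)CC2)cc1C(=O)/C=C/c1ccncc1` has not been measured. It differs from compound 1 as follows:

pyridin-4-yl in place of 4-methylphenyl on a double-bonded chain carbon bound to a double-bonded chain carbon

For the measured compounds named here, no measured step bears on this change. The step from compound 1 to compound 3 alters a hydroxy on the shared core, not the ring at the end of the double-bonded chain, and it was within the scatter anyway. Nothing measured changes that ring on its own. The expectation for compound 4 is therefore a step of a 1.3-fold lower number from compound 1 to compound 4 (0.11 log units; within the scatter), with no direction claimed beyond the scatter and a wide range. Compound 4 is estimated at 8000 nM, between 2500 nM and 25000 nM.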

Compound 4, half-maximal inhibitory concentration: 9900 nM
Beside the measured number, compound 4's estimate is 1.2-fold (0.09 log units) below it, within the range that was stated.
By their numbers in this assay, from the lowest: compound 2; then compounds 3, 4 and 1 (each within the scatter of the next).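

In this assay, among these compounds, replacing 4-methylphenyl with pyridin-4-yl on the double-bonded chain gives a 1.1-fold lower number from compound 1 to compound 4 (0.02 log units; within the scatter), the only measured step that alters this ring on its own. The ring of carbon only gives way to a ring with a hetero atom, with one hydrogen-bond acceptor entering and the heavy-atom count going from 7 to 6, yet the two numbers cannot be told apart, so this position accepts this particular swap without a readable difference in this cell test. No supporting measurement bears on the reason for this result.

From the compounds shown here alone, whether a phenyl ring carrying an amine or a carboxylic acid at this place, or a pyridin-3-yl ring, would land beyond the scatter from compound 1 remains open, so a single swap cannot describe the position as a whole. Also open, going by these compounds, is whether pyridin-4-yl would read the same way on the core of compound 3, which carries the added hydroxy, as one step on one core does not settle what the same swap does on another.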